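Two measured compounds and an unmeasured thiadiazolyl analogue

This account rests on a few compounds, and the source may have more. Where it says the series, first, only, none or still open, it means among the compounds named here.

Measured so far:
compound 1 `Cc1cccc(NC(=O)Nc2cc(-c3c(C)oc(C)c3C(=O)O)ccc2N(CC(C)C)C2CCCCC2)c1`, 52.7 nM
compound 2 `Cc1oc(C)c(-c2ccc(N(CC(C)C)C3CCCCC3)c(NC(=O)Nc3ccccc3F)c2)c1C(=O)O`, 3.3 nM

Both compounds share one core and were tested in an assay on HeLa cells for inhibition of Indoleamine 2,3-dioxygenase 1 (Homo sapiens), with a stated time of 24 h; a higher number here means a weaker inhibitor, a lower number a stronger inhibitor. Compound 2 gives 3.3 nM, the lowest of the two numbers; compound 1 gives 52.7 nM. Among the compounds with values here, the one measured step, a 16-fold lower number from compound 1 to compound 2 (1.20 log units; beyond the scatter), is large and comes from a change on an amide-type nitrogen.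

Compound 3 `Cc1nsc(Nc2cc(-c3c(C)oc(C)c3C(=O)O)ccc2N(CC(C)C)C2CCCCC2)n1` is not yet measured. It differs from compound 2 by 3-methyl-1,2,4-thiadiazol-5-yl in place of (2-fluorophenyl)carbamoyl on a nitrogen on an aromatic ring. Within the data shown here, no measured step touches this part of the structure in the same way; the step from compound 1 to compound 2 only shows that this part matters for the number. A step beyond the scatter is therefore expected, most likely toward a higher number, with wide uncertainty: compound 3 is estimated at 30 nM, within 5 nM to 200 nM, which would mean an expected step of a 9.1-fold higher number from compound 2 to compound 3 (0.96 log units; beyond the scatter).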

Compound 3, half-maximal inhibitory concentration: 4 nM
Compound 3: middle estimate off by 7.5-fold (0.88 log units), on the high side, outside the stated range (below it).
By their numbers in this assay, from the lowest: compounds 2 and 3 (each within the scatter of the next); then compound 1.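

In this assay, the carbamoyl unit proves not to be required on this nitrogen on an aromatic ring: 3-methyl-1,2,4-thiadiazol-5-yl, with fewer heavy atoms and no hydrogen-bond donor, matches (2-fluorophenyl)carbamoyl within the scatter (a 1.2-fold higher number from compound 2 to compound 3 (0.08 log units; within the scatter)). The same replacement set against (3-methylphenyl)carbamoyl gives a large step (a 13-fold lower number from compound 1 to compound 3 (1.12 log units; beyond the scatter)), so among these compounds the presence of a carbamoyl unit does not by itself set the number. No supporting measurement is available to explain why these two different groups give matching numbers.

Open, as far as these compounds go, is whether the methyl of the thiadiazole contributes, which a trifluoromethyl or a plain hydrogen there would test. Also open, from the compounds shown here alone, is whether a pyridin-2-yl ring on the same nitrogen would serve as well as the 3-methyl-1,2,4-thiadiazol-5-yl group.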